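The source may report more compounds than this note shows. Statements on the series, on what has been measured and on what is new or still open speak of the compounds shown alone.

Of the compounds shown here, three built on one shared core have been measured so far in a functional assay on MCF7 cells (Homo sapiens) for inhibition; a lower number here means a stronger inhibitor, a higher number a weaker inhibitor. Compound 1 `CC/C(=C(/c1ccc(/C=C/C(=O)O)cc1)c1cc2ccccc2[nH]1)c1ccccc1C` gives 33 nM in this assay. Compound 2 `CC/C(=C(/c1ccc(/C=C/C(=O)O)cc1)c1cc2ccccc2[nH]1)c1ccccc1Cl` gives 42 nM in this assay, and the step between them, a 1.3-fold higher number from compound 1 to compound 2 (0.10 log units; within the scatter), shows that exchanging methyl for chloro on that aromatic carbon changed little. Compound 3 `CC/C(=C(/c1ccc(/C=C/C(=O)O)cc1)c1cc2ccccc2[nH]1)c1cccc(C)c1` gives 140 nM in this assay, the highest number of the three: a 4.2-fold higher number from compound 1 to compound 3 (0.63 log units; beyond the scatter) and a 3.3-fold higher number from compound 2 to compound 3 (0.52 log units; beyond the scatter), both modest losses that came with moving the group from the 2-methylphenyl or 2-chlorophenyl to the 3-methylphenyl.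

Compound 4 `CC/C(=C(/c1ccc(/C=C/C(=O)O)cc1)c1cc2ccccc2[nH]1)c1ccc(Cl)cc1` has not yet been measured. It differs from compound 3 in one place: 4-chlorophenyl in place of 3-methylphenyl on a double-bonded chain carbon bound to a double-bonded chain carbon and a saturated chain carbon. Two of the measured steps bear on this. The methyl-to-chloro swap from compound 1 to compound 2 cost almost nothing, so chloro in place of methyl alone is not expected to move the number. Among the compounds with values here, the shift of the group from compound 1 to compound 3 cost a modest amount, and no measured compound carries a 4-chlorophenyl, so the effect of that placement is unknown. Compound 4 is therefore expected to sit near compound 3 or somewhat weaker, a step of a 1.4-fold higher number from compound 3 to compound 4 (0.15 log units; within the scatter), with an estimate of 200 nM and a range from 60 nM to 700 nM in this assay.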

Compound 4, half-maximal inhibitory concentration: 343 nM
Compound 4: middle estimate off by 1.7-fold (0.23 log units), on the low side; measured number inside the range.
By their numbers in this assay, from the lowest: compounds 1 and 2 (each within the scatter of the next); then compound 3; then compound 4.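

In this assay, the change from 2-chlorophenyl to 4-chlorophenyl keeps the chlorine and alters only where it sits on the ring, and it gives an 8.2-fold higher number from compound 2 to compound 4 (0.91 log units; beyond the scatter), so the loss seen earlier when the methyl group was moved is not limited to methyl. Within the data shown here, the 4-chlorophenyl also stands apart from the 3-methylphenyl, with a 2.5-fold higher number from compound 3 to compound 4 (0.39 log units; beyond the scatter), and it produces the only large step in the set, a 10-fold higher number from compound 1 to compound 4 (1.02 log units; beyond the scatter), which makes compound 4 the weakest of the four. Across these compounds, the 2-methylphenyl and 2-chlorophenyl groups remain within the scatter of each other, while both other placements give higher numbers, so where the group sits on the ring counts for more here than whether it is methyl or chloro.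

Nothing available explains why placement on the ring has this effect. The step to compound 4 changes both the group and its place at once, so a 3-chlorophenyl and a 4-methylphenyl would be needed to separate the two changes, and an unsubstituted phenyl would show what either group adds at all.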